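The source may hold more compounds than are shown below. What is called first, only, known or untested is meant among the compounds shown, and "the series" means these compounds.

For the measured compounds named here, in a functional assay on A2780 cells (Homo sapiens) for inhibition (a lower number here means a stronger inhibitor, a higher number a weaker inhibitor), the series so far rests on three compounds. Compound 1 `CCNC(=O)c1noc(-c2cc(C(C)C)c(O)cc2O)c1-c1cc(CO)no1` gives 5 nM, compound 3 `CCNC(=O)c1noc(-c2cc(C(C)C)c(O)cc2O)c1-c1cc(CN(C)C)no1` gives 31 nM, and for compound 2 `CCNC(=O)c1noc(-c2cc(C(C)C)c(O)cc2O)c1-c1cc(COCC(=O)O)no1` the entry reads "not determined" (no result reported). Compound 3 thus holds the higher of the two numbers available. The next compound is compound 4 `CCNC(=O)c1noc(-c2cc(C(C)C)c(O)cc2O)c1-c1cc(C(N)=O)no1`, whose difference from compound 3 is: carbamoyl in place of (dimethylamino)methyl on an aromatic carbon. In words, carbamoyl stands in place of (dimethylamino)methyl on an aromatic carbon.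

Going by the values given here, only one measured step bears on this: a 6.2-fold higher number from compound 1 to compound 3 (0.79 log units; beyond the scatter), with dimethylamino in place of hydroxy on a saturated chain carbon. Among the compounds with values here, no measured step involves carbamoyl, so this guide is a loose one. Compound 4 carries no dimethylamino group, and neither does compound 1 at 5 nM, so a move towards a lower number is expected, somewhat smaller than the measured step. The expected step is a 2.6-fold lower number from compound 3 to compound 4 (0.41 log units; beyond the scatter). For compound 4 the estimated value is 12 nM, with an expected range of 3 nM to 45 nM.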

Compound 4, half-maximal inhibitory concentration: 15 nM
Estimate against measurement, compound 4: 1.3-fold (0.10 log units) below; the range from low to high includes it.
By their numbers in this assay, from the lowest: compound 1; then compound 4; then compound 3.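

In this assay, carbamoyl sits directly on the aromatic carbon next to the ring nitrogen and recovers part of the gap opened by (dimethylamino)methyl (a 2.1-fold lower number from compound 3 to compound 4 (0.32 log units; beyond the scatter)), but it does not match hydroxymethyl (a 3.0-fold higher number from compound 1 to compound 4 (0.48 log units; beyond the scatter)). Losing the dimethylamino group is therefore not enough on its own to reach the number of compound 1, and the three groups at this position separate beyond the scatter, with compound 1 lowest and compound 3 highest. Nothing available explains this order.

Still open, on these data alone, is whether the hydroxy group itself or the saturated chain carbon that carries it sets the low number of compound 1. An aminomethyl group or a longer chain ending in hydroxy at this position would bear on that question.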